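From a sulfonyl to a pentylcarbonyl on an amine nitrogen

A few compounds are considered here, and "the series" means these few. Any claim that something is new, unique, unknown or untested is made for them only; others in the source may bear on it.

In a functional assay for inhibition, with Homo sapiens as the target (a higher number here means a weaker inhibitor, a lower number a stronger inhibitor), compound 1 (`CC(C)CS(=O)(=O)N[C@@H](CNC(=O)c1ccc2c(c1)C(=O)N(CCC1CCNCC1)C2)C(=O)O`) gives 9 nM and compound 2 (`CCOCCS(=O)(=O)N[C@@H](CNC(=O)c1ccc2c(c1)C(=O)N(CCC1CCNCC1)C2)C(=O)O`) gives 8 nM as its result. Going by the values given here, these two numbers lie within the usual scatter of each other, so compound 2 stands level with its only measured neighbour.

The next structure, compound 3 (`CCCCCC(=O)N[C@@H](CNC(=O)c1ccc2c(c1)C(=O)N(CCC1CCNCC1)C2)C(=O)O`), brings pentylcarbonyl in place of (2-ethoxyethyl)sulfonyl on an amine nitrogen. Among the compounds with values here, only one measured step bears on this change, and only loosely. Putting ethoxymethyl in place of isopropyl gave a 1.1-fold lower number from compound 1 to compound 2 (0.05 log units; within the scatter) and left the sulfonyl untouched. That step shows two sulfonyl-bearing chains giving matching results, but it says nothing about removing the sulfonyl itself. Within the data shown here, no measured compound carries pentylcarbonyl, so the evidence here is thin. A modest move towards weaker inhibition is therefore expected in this assay with wide uncertainty. The expected size is a 2.5-fold higher number from compound 2 to compound 3 (0.40 log units; beyond the scatter) as a rough estimate. For compound 3 the estimated value is 20 nM with an expected range from 7 nM to 60 nM in this test.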

Compound 3, half-maximal inhibitory concentration: 13 nM
The estimate for compound 3 lay 1.5-fold (0.19 log units) above the measured number, and the stated range covers the measured number.
By their numbers in this assay, from the lowest: compounds 2, 1 and 3 (each within the scatter of the next).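

Until now, every compound carried a sulfonyl on this amine nitrogen, and only the chain beyond it had varied. In this assay, the exchange of (2-ethoxyethyl)sulfonyl for pentylcarbonyl gives a 1.6-fold higher number from compound 2 to compound 3 (0.21 log units; within the scatter) and the exchange of isobutylsulfonyl for pentylcarbonyl gives a 1.4-fold higher number from compound 1 to compound 3 (0.16 log units; within the scatter), so all three compounds stand level and the sulfonyl is not essential for a result in this range among the compounds shown. Each of these exchanges alters both the link to the nitrogen and the chain it carries, and nothing available explains why the results match.

The effects of the link and the chain therefore remain unseparated, and a hexylsulfonyl or a (3-ethoxypropanoyl) group on the same nitrogen would be needed to pull them apart. On these data alone, it also remains open how far this tolerance extends, for example to a much shorter acetyl group, a ring-bearing benzoyl group or an amine nitrogen with a bare hydrogen in place of the acyl or sulfonyl group.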